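The compounds below may be only part of what the source reports. "The series", "measured", "known", "first", "only" and "open" are said of these compounds alone.

Compound 1 `O=C(Nc1cccc(C(F)(F)F)c1)N[C@H]1CC[C@H](Oc2cccc(C(F)(F)F)c2)CC1`: in a functional assay on CRL2813 cells (Homo sapiens) for cytotoxicity, read by sulforhodamine B assay, with a stated time of 5 days (a higher number here means a weaker inhibitor, a lower number a stronger inhibitor), compound 1 gives 1300 nM.
Compound 2 `O=C(Nc1ccccc1C(=O)O)N[C@H]1CC[C@@H](Oc2ccc(F)cc2)CC1`: compound 2 reaches only a limit of this assay, > 20000 nM.
Compound 3 `CSc1ccc(NC(=O)N[C@H]2CC[C@H](Oc3ccc(F)cc3)CC2)cc1`: compound 3 likewise reaches only a limit of this assay, > 20000 nM.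

Compound 3 therefore stands at the limit of > 20000 nM in this assay, at which 2 of the 3 values shown sit, with no number of its own; only compound 1 gives a measurable value. The unmeasured compound 4 `O=C(Nc1cccc(C(=O)O)c1)N[C@H]1CC[C@H](Oc2ccc(F)cc2)CC1` differs from compound 3 by 3-carboxyphenyl in place of 4-(methylsulfanyl)phenyl on an amide-type nitrogen. Going by the values given here, no measured pair in this set isolates that change. Compound 2, which also carries a carboxyphenyl group on the urea nitrogen, sits at the limit, so the estimated step that the limit leaves unreadable from compound 3 to compound 4 from compound 3 to compound 4 is expected to be none beyond the scatter. Compound 4 is thus estimated at 25000 nM, within 8000 nM to 80000 nM.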

Compound 4, half-maximal inhibitory concentration: > 20000 nM
Compound 4: no number, only a limit (the forecaster's own chance of this, stated with the estimate: 75%); the middle value does not contradict the limit.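

Compound 3 and compound 4 both sit at a limit of this assay, so no step can be read between them: the limit of > 20000 nM in this assay, at which 3 of the 4 values shown sit.

The compounds shown leave open whether 3-carboxyphenyl in place of 4-(methylsulfanyl)phenyl on an amide-type nitrogen changes the result in this assay at all.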